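The compounds below may be only part of what the source reports. "The series", "measured", "known", "first", "only" and "open" are said of these compounds alone.

Compound 1, `COc1cc(-c2cc(/C=C/C(=O)c3ccc(N)cc3)[nH]n2)cc(OC)c1OC`, gives 103% in a functional assay on NCI-H322M cells (Homo sapiens) for cytotoxicity, read by sulforhodamine B assay, with a stated time of 48 h, tested at 0.1 uM; a lower number here means a stronger effect, a higher number a weaker effect of the compound at the concentration tested.
Compound 2, `COc1ccc(-c2cc(/C=C/C(=O)c3ccc(N)cc3)[nH]n2)cc1OC`, gives 102% in this assay.
Compound 3, `COc1cc(C(=O)/C=C/c2cc(-c3cc(OC)c(OC)c(OC)c3)n[nH]2)cc(OC)c1OC`, gives 97% in this assay.

All three numbers sit close together, and none of them can be set apart from the others. Compound 1 and compound 2 differ in a single place: hydrogen in place of methoxy on an aromatic carbon. The step this made in this assay was a number 1 percentage points lower from compound 1 to compound 2 (within the scatter), so the compound kept essentially the same read-out after the change.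

Compound 4, `COc1ccc(-c2cc(/C=C/C(=O)c3cc(OC)c(OC)c(OC)c3)[nH]n2)cc1OC`, has not yet been measured. It stands to compound 3 as compound 2 stands to compound 1: hydrogen in place of methoxy on an aromatic carbon. The surroundings of the change are described in the same words in both pairs, so this is the same change made on a different core. How the core of compound 3 differs from the core of compound 1 is not broken down here.

Since compound 3 gives 97%, and the same change in the earlier pair gave a number 1 percentage points lower from compound 1 to compound 2 (within the scatter), the step expected from compound 3 to compound 4 is no change at the digits printed from compound 3 to compound 4 (within the scatter). Compound 4 is therefore expected to give about 97% in this assay, most likely between 85% and 108%.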

Compound 4, a percentage reported as activity, at one concentration (the size of the read-out at that concentration, not a potency): 88%
Estimate against measurement, compound 4: 9 percentage points above; low and high end bracket the measured number.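

In this assay, putting hydrogen in place of methoxy on the core of compound 3 gave a number 9 percentage points lower from compound 3 to compound 4 (within the scatter). Set beside the earlier pair, the change cannot be told apart on the two cores: the same change on two cores in this assay, a number 1 percentage points lower (within the scatter) from compound 1 to compound 2 and a number 9 percentage points lower (within the scatter) from compound 3 to compound 4, 8 percentage points apart, within the scatter of two such steps. Going by these compounds alone, this shows that on these two cores the change leaves the read-out within the usual scatter at the one concentration tested, but it does not show that the change is without effect at other concentrations, in other cells or on other cores, and with no step standing clear of the scatter, these pairs are only a weak test of whether an effect carries from one core to another.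

The compounds shown have only methoxy or hydrogen at this place, so it remains open how a different group there, such as a hydroxyl, a fluorine or an amine, would read in this assay. From the compounds shown here alone, a longer chain such as ethoxy also remains open, as does whether any such group would move the read-out clear of the scatter.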